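The compounds below may be only part of what the source reports. "The series", "measured", "known", "first", "only" and "open" are said of these compounds alone.

Compound 2 `CN(C)CCn1cnnc1-c1cc(Oc2ccc(NC(=O)N/N=C/c3ccc(F)cc3F)cc2F)ccn1` and compound 1 `CN(C)CCn1cnnc1-c1cc(Oc2ccc(NC(=O)N/N=C/c3c(Cl)cccc3Cl)cc2F)ccn1` share the same core and differ only in the aryl group sitting on a carbon with a double bond to nitrogen. In an ADME assay on WI-38 cells (Homo sapiens) for cytotoxicity, read by MTT assay, with a stated time of 72 h (on this read-out higher numbers stand for weaker inhibition and lower numbers for stronger inhibition), compound 1 gives 3320 nM and compound 2 gives 5030 nM. On the numbers shown, compound 2 sits at the top of the two, yet the only step between them, a 1.5-fold higher number from compound 1 to compound 2 (0.18 log units; within the scatter), is within the scatter, so the two numbers cannot really be told apart on this read-out. Compound 3 `CN(C)CCn1cnnc1-c1cc(Oc2ccc(NC(=O)N/N=C/c3cccc(Cl)c3Cl)cc2F)ccn1` has not yet been measured; it differs from compound 2 by 2,3-dichlorophenyl in place of 2,4-difluorophenyl on a carbon with a double bond to nitrogen. Among the measured compounds shown here, the one measured step that bears on this change is the earlier swap of one aryl group for another on that same carbon, a 1.5-fold higher number from compound 1 to compound 2 (0.18 log units; within the scatter), which did not move the number beyond the scatter. On that basis the step of a 1.3-fold lower number from compound 2 to compound 3 (0.10 log units; within the scatter) is expected to be small, with no clear direction beyond the scatter. Compound 3 is therefore estimated at 4000 nM, with a range from 1500 nM to 11000 nM.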

Compound 3, half-maximal inhibitory concentration: 6130 nM
Estimate against measurement, compound 3: 1.5-fold (0.19 log units) below; the range from low to high includes it.
By their numbers in this assay, from the lowest: compounds 1, 2 and 3 (each within the scatter of the next).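

In this assay, putting 2,3-dichlorophenyl in place of 2,4-difluorophenyl gives a 1.2-fold higher number from compound 2 to compound 3 (0.09 log units; within the scatter), so exchanging this pair of fluorine atoms for this pair of chlorine atoms on the aryl group does not separate the two compounds. The new compound also tests a second kind of change. Putting 2,3-dichlorophenyl in place of 2,6-dichlorophenyl keeps both chlorine atoms and alters only their arrangement on the ring, and this gives a 1.8-fold higher number from compound 1 to compound 3 (0.27 log units; within the scatter). Across these three aryl groups on a carbon with a double bond to nitrogen, no listed step leaves the scatter, and nothing measured here offers a reason for that.

All three groups shown are phenyl rings carrying two halogen atoms, so it remains open whether a plain phenyl, a pyridine ring, or a phenyl bearing an amine or a carboxylic acid at this place would shift the number beyond the scatter. From the compounds shown here alone, it also remains open whether changes elsewhere on the shared core would matter more than this aryl group does.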